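The compounds below may be only part of what the source reports. "The series", "measured", "known", "first", "only" and "open" are said of these compounds alone.

Compound 3 `Cn1c(=O)c(S(=O)(=O)c2ccc(F)cc2F)cc2cnc(Nc3ccc4occc4c3)nc21` is the weakest of the three compounds measured here: in a functional assay on K562 cells (Homo sapiens) for inhibition, read by trypan blue exclusion, with a stated time of 72 h (on this read-out higher numbers stand for weaker inhibition and lower numbers for stronger inhibition), compound 3 gives 15000 nM. For the measured compounds named here, its nearest neighbour is compound 1 `Cn1c(=O)c(S(=O)(=O)c2ccc(F)cc2)cc2cnc(Nc3ccc4occc4c3)nc21`, which in this assay gives 5000 nM, so that the step of a 3.0-fold higher number from compound 1 to compound 3 (0.48 log units; beyond the scatter) is the only single change recorded, and it concerns the fluoro group, not the amine substituent. Compound 2 `COc1ccc(S(=O)(=O)c2cc3cnc(Nc4ccc5[nH]ccc5c4)nc3n(C)c2=O)cc1` differs from compound 3 in two places at once; in this assay compound 2 gives 300 nM. Going by the values given here, no single step links compound 2 to compound 3, and its value shows only that the indole-bearing compound is far stronger.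

Compound 4 `Cn1c(=O)c(S(=O)(=O)c2ccc(F)cc2F)cc2cnc(NCc3ccc4[nH]ccc4c3)nc21` carries the change ((1H-indol-5-yl)methyl in place of 1-benzofuran-5-yl on a nitrogen on an aromatic ring). Among the compounds with values here, no measured step touches this part of the molecule. The indole of compound 2 sits directly on the nitrogen, without the methylene, and comes with a different sulfonyl ring, so its value cannot be read as a guide. Within the data shown here, with no relevant step to lean on, the direction is open; the estimate leans toward weaker inhibition. Compound 4 is therefore expected to read 30000 nM in this assay, with a range from 6000 nM to 100000 nM, which would mean a step of a 2.0-fold higher number from compound 3 to compound 4 (0.30 log units; within the scatter).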

Compound 4, half-maximal inhibitory concentration: 75000 nM
Compound 4: the middle estimate sits 2.5-fold (0.40 log units) below what was measured; low and high end bracket the measured number.
By their numbers in this assay, from the lowest: compound 2; then compound 1; then compound 3; then compound 4.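

For the compounds shown here, the step, a 5.0-fold higher number from compound 3 to compound 4 (0.70 log units; beyond the scatter), is the first measured change at the group on the amine nitrogen, and in this assay it runs toward weaker inhibition. Until now, the only single change measured among these compounds was the fluoro step, a 3.0-fold higher number from compound 1 to compound 3 (0.48 log units; beyond the scatter), so this result shows that the group on this nitrogen also moves the number beyond the scatter, in the same direction, when (1H-indol-5-yl)methyl takes the place of 1-benzofuran-5-yl. Nothing given here bears on why the number rises.

The step changes two things together, the hetero atom of the five-membered ring and the methylene link, so the compounds shown leave open which of them accounts for the change, or whether both contribute. A (1-benzofuran-5-yl)methyl group or a directly attached 1H-indol-5-yl group on this nitrogen, with the sulfonyl ring of compound 3 kept in place, would pull the two changes apart, and a 2-(1H-indol-5-yl)ethyl chain would test the length of the link.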